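A few compounds are considered here, and "the series" means these few. Any claim that something is new, unique, unknown or untested is made for them only; others in the source may bear on it.

Measured so far in an ADME assay on cells (Fibroblast, Gallus gallus) for cytotoxicity, read by CCK-8 assay, with a stated time of 48 h (on this read-out higher numbers stand for lower toxicity in this test and lower numbers for higher toxicity in this test), each entry being a limit of the assay and not a number:

Compound 1 `CCC(CC)O[C@@H]1C=C(C(=O)O)C[C@H](NCc2ccc(OC)cc2)[C@H]1NC(C)=O`: > 200000 nM
Compound 2 `CCC(CC)O[C@@H]1C=C(C(=O)O)C[C@H](NCc2ccc(Oc3ccccc3)cc2)[C@H]1NC(C)=O`: > 200000 nM
Compound 3 `CCC(CC)O[C@@H]1C=C(C(=O)O)C[C@H](NCc2ccc(Sc3ccccc3)cc2)[C@H]1NC(C)=O`: > 200000 nM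

Compound 3 gives > 200000 nM, which is a limit of the assay and not a number. It therefore has no exact place among the three compounds, and all of them share one reading: the limit of > 200000 nM in this assay, at which 3 of the 3 values shown sit.

The next compound, compound 4 `CCC(CC)O[C@@H]1C=C(C(=O)O)C[C@H](NCc2ccc(S(=O)(=O)c3ccccc3)cc2)[C@H]1NC(C)=O`, keeps the shared core and changes one group, with phenylsulfonyl in place of phenylsulfanyl on an aromatic carbon.

Each of the three measured steps swaps this same group. They are a step that the two limits leave unreadable from compound 1 to compound 2, a step that the two limits leave unreadable from compound 1 to compound 3 and a step that the two limits leave unreadable from compound 2 to compound 3. None of them has a readable size, yet none of these swaps brought a number into view. Going by the limit of > 200000 nM in this assay, at which 3 of the 3 values shown sit, the expectation is that compound 4 also stays at the limit in this assay, with no change in either direction that could be read. The expected change is a number no higher from compound 3 to compound 4 (the limit leaves the size open), which is an estimate and not a measurement.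

For compound 4 the estimate is 200000 nM, with an expected range from 100000 nM to 400000 nM.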

Compound 4, half-maximal cytotoxic concentration: > 200000 nM
Compound 4 gave a limit, no number (the forecaster's own chance of this, stated with the estimate: 85%); the middle value lies on the limit itself.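

In this assay compound 4 gives > 200000 nM, which is a limit of the assay and not a number. The steps joining compound 4 to compound 1, compound 2 and compound 3 therefore cannot be read, as all four share one reading: the limit of > 200000 nM in this assay, at which 4 of the 4 values shown sit. The compounds shown leave open at what concentration any of the four would become toxic to the cells, and whether their groups differ at all in this assay.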